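The source may report more compounds than this note shows. Statements on the series, on what has been measured and on what is new or still open speak of the compounds shown alone.

Measured compounds in an ADME assay on HFF cells (Homo sapiens) for cytotoxicity, with a stated time of 8 days; a higher number here means that more compound is tolerated, a lower number that less compound is tolerated:

Compound 1 `Nc1nc(OCC(F)(F)F)c2ncn(/C=C3/CC3(CO)CO)c2n1` gives > 300000 nM in this assay, which is a limit and not a number.
Compound 2 `Nc1nc2c(ncn2/C=C2/CC2(CO)CO)c(=O)[nH]1` gives > 300000 nM in this assay, again a limit rather than a number.

Within the data shown here, compound 1 stands at the limit, and so does the one other value shown: the limit of > 300000 nM in this assay, at which 2 of the 2 values shown sit. Neither value is a number. Among the measured compounds shown here, no step between measured compounds can be given a size; the two values show only that compound 1 and compound 2 both sit at the same limit. Compound 3 `CCCCCCOc1nc(N)nc2c1ncn2/C=C1/CC1(CO)CO` has not yet been tested in this assay. It differs from compound 1 in one place: pentyl in place of trifluoromethyl on a saturated chain carbon bound to an oxygen on an aromatic ring. With both measured values at the limit, the step from compound 1 to compound 3 in this assay is expected to be an at least 1.2-fold lower number from compound 1 to compound 3 (0.07 log units; that floor lies within the scatter), nothing beyond the scatter. Compound 3 is therefore estimated to give 250000 nM in this assay, with a range from 80000 nM to 600000 nM, and a fair chance that only a limit is reported again.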

Compound 3, half-maximal cytotoxic concentration: > 200000 nM
Compound 3: no number, only a limit (the forecaster's own chance of this, stated with the estimate: 60%); the middle value is on the limit's open side.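

Among these compounds, compound 3 gives > 200000 nM in this assay, which is a limit and not a number, and compound 1 also stands at a limit, so no step between compound 1 and compound 3 can be read. From the compounds shown here alone, how far either compound is tolerated beyond its limit stays open.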